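Side-chain variation on the shared core: chain to ring

The source may report more compounds than this note shows. Statements on the series, on what has been measured and on what is new or still open speak of the compounds shown alone.

Measured so far:
- compound 1, `CC(C)(F)CCn1nc(-c2cccs2)c(O)c(C2=NS(=O)(=O)c3cc(OCC(N)=O)ccc3N2)c1=O`, 0.65 h in an in vitro ADME assay on microsomes from liver (Homo sapiens) for metabolic stability; a lower number here means that the compound disappears faster, a higher number that the compound lasts longer
- compound 2, `CCC(C)CCn1nc(-c2cccs2)c(O)c(C2=NS(=O)(=O)c3cc(OCC(N)=O)ccc3N2)c1=O`, 0.417 h

Compound 2 gives the lowest of the two numbers in this assay; its nearest neighbour is compound 1, and the step of a 1.6-fold lower number from compound 1 to compound 2 (0.19 log units; within the scatter) is within the scatter, so the two stand level.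

Compound 3 is `NC(=O)COc1ccc2c(c1)S(=O)(=O)N=C(c1c(O)c(-c3cccs3)nn(CC3CCCC3)c1=O)N2`. Its difference from compound 2 is cyclopentyl in place of 2-methylbutyl on a saturated chain carbon bound to an aromatic nitrogen.

For the measured compounds named here, the only measured step that touches this region of the molecule is the one from compound 1 to compound 2, and that step stayed within the scatter. Going by the values given here, no measured step replaces an open chain with a ring at this position, so the direction of any effect is not known from the data. The expected step of a 1.2-fold higher number from compound 2 to compound 3 (0.08 log units; within the scatter) is therefore none beyond the scatter.

Compound 3 is estimated at 0.5 h in this assay, with a range from 0.2 h to 1.3 h.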

Compound 3, half-life: 0.433 h
Compound 3: the middle estimate sits 1.2-fold (0.06 log units) above what was measured; the range from low to high includes it.
By their numbers in this assay, from the lowest: compounds 2, 3 and 1 (each within the scatter of the next).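

With the count held at five carbon atoms, cyclopentyl in place of 2-methylbutyl on a saturated chain carbon bound to an aromatic nitrogen gives (a 1.0-fold higher number from compound 2 to compound 3 (0.02 log units; within the scatter)) in this assay, so this swap of open chain for ring leaves the half-life level. Cyclopentyl in place of 2-fluoro-2-methylpropyl gives (a 1.5-fold lower number from compound 1 to compound 3 (0.18 log units; within the scatter)), which also stays within the scatter. Across these compounds, neither the ring nor the fluorine separates one compound from another in this assay, and no supporting data offer an explanation for this flat result.

Still open, on these data alone, is whether any group at this place moves the half-life beyond the scatter, for instance an amine, a carboxylic acid or a longer chain. A six-membered ring such as cyclohexyl would test whether ring size matters here.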